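This account rests on a few compounds, and the source may have more. Where it says the series, first, only, none or still open, it means among the compounds named here.

Series notes. In an ADME assay on L6 cells (Rattus norvegicus) for cytotoxicity, read by resazurin assay, with a stated time of 72 h (on this read-out lower numbers stand for an effect already at smaller amounts and higher numbers for an effect only at larger amounts of compound), compound 3 `CCOC(=O)C1=C(C)N/C(=C/c2cc(C)n(-c3cccc(O)c3)c2C)C1=O` gives 69000 nM. Compound 1 `CCOC(=O)C1=C(C)N/C(=C/c2cc(C)n(-c3ccc(CN(C)C)cc3)c2C)C1=O` gives 120000 nM, and compound 2 `CCOC(=O)C1=C(C)N/C(=C/c2cc(C)n(-c3ccc(N(C)C)cc3)c2C)C1=O` gives 180000 nM. Of the steps that lead onto compound 3, a 1.7-fold lower number from compound 1 to compound 3 (0.24 log units; within the scatter) stays within the scatter, while a 2.6-fold lower number from compound 2 to compound 3 (0.42 log units; beyond the scatter) is modest but beyond it; between the other two, a 1.5-fold higher number from compound 1 to compound 2 (0.18 log units; within the scatter). Compound 4 `CCOC(=O)C1=C(C)N/C(=C/c2cc(C)n(-c3cccnc3)c2C)C1=O` differs from compound 3 by pyridin-3-yl in place of 3-hydroxyphenyl on an aromatic nitrogen. The two earlier swaps of the aryl group on the same aromatic nitrogen, a 1.7-fold lower number from compound 1 to compound 3 (0.24 log units; within the scatter) and a 2.6-fold lower number from compound 2 to compound 3 (0.42 log units; beyond the scatter), moved the number little, so no step beyond the scatter is expected in this assay for this change either. Compound 4 is therefore estimated at 90000 nM, with a range of 45000 nM to 180000 nM, an expected 1.3-fold higher number from compound 3 to compound 4 (0.12 log units; within the scatter).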

Compound 4, half-maximal effective concentration: 160000 nM
Beside the measured number, compound 4's estimate is 1.8-fold (0.25 log units) below it, and the stated range covers the measured number.
By their numbers in this assay, from the lowest: compounds 3, 1, 4 and 2 (each within the scatter of the next, the first and the last beyond it).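

On this aromatic nitrogen in this assay, a 2.3-fold higher number from compound 3 to compound 4 (0.37 log units; beyond the scatter) is modest but beyond the scatter, so here the swap of 3-hydroxyphenyl for pyridin-3-yl gives a readable step. The other two steps, a 1.1-fold lower number from compound 2 to compound 4 (0.05 log units; within the scatter) and a 1.3-fold higher number from compound 1 to compound 4 (0.12 log units; within the scatter), stay within the scatter, so pyridin-3-yl cannot be told apart from either dimethylamino-bearing aryl group. Nothing at hand explains the step. Open, as far as these compounds go, is whether the hydroxyl itself carries the difference: 3-methoxyphenyl or 3-aminophenyl on the same nitrogen would test this.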